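Adding a dimethylamino group to a quinoline amine: expected lipophilicity

The source may hold more compounds than are shown below. What is called first, only, known or untested is meant among the compounds shown, and "the series" means these compounds.

Of the compounds shown here, two built on a shared core have been measured so far. Compound 1 `Clc1ccc2c(NCc3ccc(CN4CCCC4)s3)ccnc2c1` and compound 2 `Clc1ccc2c(NCc3nc(-c4ccccc4)c[nH]3)ccnc2c1` were both run in a physicochemical assay for lipophilicity, at pH 7.4; a lower number here means a more polar compound, a higher number a more lipophilic compound. In this assay compound 1 gives 4.42, and compound 2 gives 4.98. Among the compounds with values here, compound 2 therefore stands as the higher of the two numbers, with compound 1 its only neighbour at a distance beyond the usual scatter. Within the data shown here, no pair of these measured compounds differs in a single place, so no measured step is available to lean on.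

Compound 3 `CN(C)c1cccc(-c2c[nH]c(CNc3ccnc4cc(Cl)ccc34)n2)c1` has not yet been measured. It differs from compound 2 in one place: dimethylamino in place of hydrogen on an aromatic carbon. The entering group brings one hydrogen-bond acceptor and no ring.

For this change the step from compound 2 to compound 3 in this assay is expected to be small and upward, possibly no larger than the scatter itself, giving a number 0.22 log units higher from compound 2 to compound 3 (within the scatter). On that basis compound 3 is estimated to reach 5.2 in this assay, with a likely range from 4.7 to 5.7.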

Compound 3, partition coefficient: 5.86
Estimate against measurement, compound 3: 0.66 log units below; the whole stated range lies below it.
By their numbers in this assay, from the lowest: compound 1; then compound 2; then compound 3.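

In this assay, within the data shown here, replacing one hydrogen on the phenyl ring of compound 2 with a dimethylamino group, which makes the 3-(dimethylamino)phenyl of compound 3, gives a number 0.88 log units higher from compound 2 to compound 3 (beyond the scatter) and so provides the first measured step. It shows that a change at this aromatic carbon, meta to a large group, can move the number by more than the usual scatter, and that here the number rises with a group that brings a hydrogen-bond acceptor and no ring. No measurement available here accounts for the direction or size of this step.

This single step cannot show whether the rise comes from the dimethylamino group specifically or whether other groups on the same aromatic carbon, such as a methoxy group, a primary amine or a carboxylic acid, would shift the number similarly or in the opposite direction. It also leaves open whether a longer chain on the nitrogen, such as diethylamino in place of dimethylamino, would extend the step, and whether the same change on another compound in the series would give a similar result.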